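This account rests on a few compounds, and the source may have more. Where it says the series, first, only, none or still open, it means among the compounds named here.

Measured so far, in a functional assay on HT-29 cells (Homo sapiens) for cytotoxicity, read by MTT assay, with a stated time of 72 h; on this read-out lower numbers stand for stronger inhibition and higher numbers for weaker inhibition:
compound 1 `CN(C)CCn1cnnc1-c1cc(Oc2ccc(NC(=O)N/N=C/c3ccc(O)c(F)c3)cc2F)ccn1` gives 3310 nM;
compound 2 `CN(C)CCn1cnnc1-c1cc(Oc2ccc(NC(=O)N/N=C/c3c(O)ccc4ccccc34)cc2F)ccn1` gives 670 nM;
compound 3 `Cn1cnnc1-c1cc(Oc2ccc(NC(=O)N/N=C/c3ccccc3)cc2F)ccn1` gives 8790 nM.

On these numbers compound 2 stands lowest, with compound 1 nearest and compound 3 furthest. Within the data shown here, the one step measured in one place is the move a 4.9-fold lower number from compound 1 to compound 2 (0.69 log units; beyond the scatter), which bears directly on the case at hand. Compound 4 `COc1cc(/C=N/NC(=O)Nc2ccc(Oc3ccnc(-c4nncn4CCN(C)C)c3)c(F)c2)ccc1O` undoes much of that move: 4-hydroxy-3-methoxyphenyl in place of 2-hydroxynaphthalen-1-yl on a carbon with a double bond to nitrogen. Since a single six-membered ring in place of the two-ring group accompanied a higher number in compound 1 at 3310 nM, compound 4 is expected to give a higher number than compound 2, with a step of about a 3.7-fold higher number from compound 2 to compound 4 (0.57 log units; beyond the scatter). The expected value for compound 4 is 2500 nM, within 900 nM to 7000 nM.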

Compound 4, half-maximal inhibitory concentration: 120 nM
Beside the measured number, compound 4's estimate is 21-fold (1.32 log units) above it, outside the stated range (below it).
By their numbers in this assay, from the lowest: compound 4; then compound 2; then compound 1; then compound 3.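

In this assay, 4-hydroxy-3-methoxyphenyl in place of 2-hydroxynaphthalen-1-yl gives a 5.6-fold lower number from compound 2 to compound 4 (0.75 log units; beyond the scatter) on this carbon with a double bond to nitrogen, so the two-ring group is not needed for a low number. Methoxy in place of fluoro on an aromatic carbon gives a 28-fold lower number from compound 1 to compound 4 (1.44 log units; beyond the scatter) within single-ring compounds, and compound 1 shows that a single ring alone does not give a low number. Nothing measured here explains these steps.

From the compounds shown here alone, whether ethoxy or chloro on that aromatic carbon would match methoxy remains open.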